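Methoxy to Butyl on Two Related Cores

The source may report more compounds than this note shows. Statements on the series, on what has been measured and on what is new or still open speak of the compounds shown alone.

Of the compounds shown here, three have been measured in a functional assay on the whole organism with Rattus norvegicus as the target, at a dose of 1 mg/kg by the oral route; on this read-out higher numbers stand for a stronger effect at the one dose given and lower numbers for a weaker effect. Compound 1 `COc1ccc(-c2cc(Cl)cc(C(=O)Nc3nn[nH]n3)n2)cc1` gives 43%. Compound 2 `CCCCc1ccc(-c2cc(Cl)cc(C(=O)Nc3nn[nH]n3)n2)cc1` carries butyl in place of methoxy on an aromatic carbon and gives 0%; the step is a number 43 percentage points lower from compound 1 to compound 2 (beyond the scatter). Compound 3 `COc1cc(C(=O)Nc2nn[nH]n2)nc(-c2ccccc2)c1` gives 62%, the highest of the three numbers, with compound 1 nearest to it and compound 2 furthest. The difference between the core of compound 1 and the core of compound 3 is not broken down here.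

Compound 4 `CCCCc1cc(C(=O)Nc2nn[nH]n2)nc(-c2ccccc2)c1` has not yet been measured in this assay. It differs from compound 3 by butyl in place of methoxy on an aromatic carbon. Within the data shown here, this is the same kind of change as the one from compound 1 to compound 2, but the place is not the same: in compound 1 the changed carbon sits in a six-membered aromatic ring of carbon only, para to a large group, whereas in compound 3 it sits in a six-membered aromatic ring with 1 nitrogen, meta to a group of 8 heavy atoms, meta to a phenyl group and opposite the ring nitrogen. Among the measured compounds shown here, the one measured instance of this change is the step of a number 43 percentage points lower from compound 1 to compound 2 (beyond the scatter). For compound 4 the expected step is a number 42 percentage points lower from compound 3 to compound 4 (beyond the scatter), which rests on that earlier step, with a wider range since the surroundings of the change differ. Compound 4 is therefore estimated at 20% in this assay, expected to lie between 0% and 50%.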

Compound 4, a percentage reported as inhibition, in the whole organism at one dose (the size of the read-out at that dose, not a potency): 56%
For compound 4 the middle estimate is 36 percentage points below the measured one; the whole stated range lies below it.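

On the core of compound 3, butyl in place of methoxy gives a number 6 percentage points lower from compound 3 to compound 4 (within the scatter) in this assay, so the large step seen on the core of compound 1 does not carry over to this second core, and the two measured instances of the change disagree: the same change on two cores in this assay, a number 43 percentage points lower (beyond the scatter) from compound 1 to compound 2 and a number 6 percentage points lower (within the scatter) from compound 3 to compound 4, 37 percentage points apart, beyond the scatter of two such steps

In this series, then, the size of the step cannot be taken from one core and applied to another, even when the groups that leave and enter are the same. The result does not show which feature decides the size of the step, since the two cores are not the same and the changed carbon sits in a different place on each; nor does it show how the change would behave on any further core, and a read-out at one dose says nothing about potency.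

The compounds shown leave open how a longer chain, an amine or a carboxylic acid would fare on the carbon opposite the ring nitrogen in the core of compound 3. They also leave open what the same exchange would give on the phenyl group of compound 3, which would test the place of the change on that core.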